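Series notes: replacing 3,4-dihydroxyphenyl with 4-bromophenyl

A few compounds are considered here, and "the series" means these few. Any claim that something is new, unique, unknown or untested is made for them only; others in the source may bear on it.

Measured in a functional assay on microsomes from liver (Rattus norvegicus, strain Wistar) for inhibition, with a stated time of 15 min; on this read-out lower numbers stand for stronger inhibition and higher numbers for weaker inhibition:
- compound 1 `COc1ccc(NC(=O)N2N=C(c3cc4ccccc4o3)CC2c2ccc(O)c(OC)c2)cc1`: 29000000 nM
- compound 2 `COc1cc(C2CC(c3cc4ccccc4o3)=NN2C(=O)Nc2ccc([N+](=O)[O-])cc2)ccc1O`: 113000000 nM
- compound 3 `COc1cc(C2CC(c3cc4ccccc4o3)=NN2C(=O)Nc2ccc(O)c(O)c2)ccc1O`: 11000000 nM

Compound 3 gives 11000000 nM, the lowest of the three numbers, so any step away from it starts from the low end of this small set.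

The next compound is compound 4 `COc1cc(C2CC(c3cc4ccccc4o3)=NN2C(=O)Nc2ccc(Br)cc2)ccc1O`, which has 4-bromophenyl in place of 3,4-dihydroxyphenyl on an amide-type nitrogen.

Two measured steps change the same place: a 2.6-fold lower number from compound 1 to compound 3 (0.42 log units; beyond the scatter), which is modest, and a 10-fold lower number from compound 2 to compound 3 (1.01 log units; beyond the scatter), which is large. Read in reverse, both show a higher number when 3,4-dihydroxyphenyl is lost. A third step, a 3.9-fold higher number from compound 1 to compound 2 (0.59 log units; beyond the scatter), is modest and separates the two other substituted phenyl groups. Among the compounds with values here, no measured compound carries bromine, so the size of the new step is poorly bounded. Its direction follows the two steps above, and its size is expected to lie nearer the modest one than the large one.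

The expected change in this assay is a 3.6-fold higher number from compound 3 to compound 4 (0.56 log units; beyond the scatter), a step toward weaker inhibition.

For compound 4 the estimated value is 40000000 nM, with an expected range from 12000000 nM to 130000000 nM.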

Compound 4, half-maximal inhibitory concentration: 115000000 nM
The estimate for compound 4 lay 2.9-fold (0.46 log units) below the measured number; measured number inside the range.
By their numbers in this assay, from the lowest: compound 3; then compound 1; then compounds 2 and 4 (each within the scatter of the next).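

In this assay the loss of 3,4-dihydroxyphenyl on the amide-type nitrogen now gives a large step with a further replacement group (a 10-fold higher number from compound 3 to compound 4 (1.02 log units; beyond the scatter)), so compound 3 stands apart from all three other compounds, with each of its steps to them beyond the scatter. Bromo and nitro on the aromatic carbon do not separate (a 1.0-fold higher number from compound 2 to compound 4 (0.01 log units; within the scatter)), which shows that the high end of this set is not held by compound 2 alone. Bromo in place of methoxy gives a modest step (a 4.0-fold higher number from compound 1 to compound 4 (0.60 log units; beyond the scatter)) in the same direction as nitro in place of methoxy (a 3.9-fold higher number from compound 1 to compound 2 (0.59 log units; beyond the scatter)), so among these four compounds the 4-methoxyphenyl group of compound 1 holds a middle place, and no compound goes against that order.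

The compounds shown leave open whether both hydroxyl groups of 3,4-dihydroxyphenyl are needed, since a 4-hydroxyphenyl group, or a phenyl carrying an amine or a carboxylic acid, is not among them. No measurement shown bears on why compound 3 gives the lowest number.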